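The compounds below may be only part of what the source reports. "The series", "measured", "known", "first", "only" and "open" are said of these compounds alone.

Compound 2 `COc1ccccc1CSc1nc2ccccc2n1CC(=O)O` stands at the top of the two numbers to hand, with 1100 nM in an assay on HEK293 cells for displacement of a labelled ligand from prostaglandin D2 receptor 2 (Homo sapiens); a higher number here means a weaker inhibitor, a lower number a stronger inhibitor; compound 1 `O=C(O)Cn1c(SCCc2ccccc2)nc2ccccc21` gives 881 nM in this assay, and the gap between them lies within the scatter, so neither separates from the other. Compound 3 `Cc1ccccc1CSc1nc2ccccc2n1CC(=O)O` carries methyl in place of methoxy on an aromatic carbon. For the measured compounds named here, no measured pair shows this change, so the step is expected to be a 1.1-fold lower number from compound 2 to compound 3 (0.04 log units; within the scatter), nothing beyond the scatter in either direction. On that basis compound 3 is estimated at 1000 nM, within a range from 400 nM to 2500 nM.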

Compound 3, half-maximal inhibitory concentration: 810 nM
Beside the measured number, compound 3's estimate is 1.2-fold (0.09 log units) above it, within the range that was stated.
By their numbers in this assay, from the lowest: compounds 3, 1 and 2 (each within the scatter of the next).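

In this assay, methyl in place of methoxy on an aromatic carbon, ortho to a large group, gives a 1.4-fold lower number from compound 2 to compound 3 (0.13 log units; within the scatter) and so shows that this position takes the smaller group without a change beyond the scatter. The change of 2-methylphenyl in place of benzyl gives a 1.1-fold lower number from compound 1 to compound 3 (0.04 log units; within the scatter) and likewise does not separate the two compounds. Nothing measured on hand explains these results.

Open, as far as these compounds go, is whether a chloro, hydroxyl or amine group at this position, or a longer chain on the sulfur, would move the number beyond the scatter.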